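A few compounds are considered here, and "the series" means these few. Any claim that something is new, unique, unknown or untested is made for them only; others in the source may bear on it.

Measured compounds:
compound 1 `CCOC(=O)C1=Cc2ccccc2OC1(OCc1cn(-c2ccc(F)cc2)nn1)C(F)(F)F` gives 8400 nM in a functional assay on HeLa cells (Homo sapiens) for inhibition, read by MTT assay, with a stated time of 24 h; on this read-out lower numbers stand for stronger inhibition and higher numbers for weaker inhibition;
compound 2 `CCOC(=O)C1=Cc2ccccc2OC1(OCc1cn(CC(=O)Nc2ccc(OC)cc2)nn1)C(F)(F)F` gives 31900 nM in this assay;
compound 3 `O=C(O)C1=Cc2ccccc2OC1(OCc1cc(-c2ccc([N+](=O)[O-])cc2)no1)C(F)(F)F` reaches only a limit of the assay, > 150000 nM, in this assay.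

Going by the values given here, compound 2 stands at the higher of the two numbers known in this assay; its nearest neighbour is compound 1, the step being a 3.8-fold higher number from compound 1 to compound 2 (0.58 log units; beyond the scatter). The third value, that of compound 3, is a limit and not a number.

Compound 4 `CCOC(=O)C1=Cc2ccccc2OC1(OCc1cn(-c2ccc(F)c(Cl)c2)nn1)C(F)(F)F` is not yet measured. It differs from compound 2 by 3-chloro-4-fluorophenyl in place of ((4-methoxyphenyl)carbamoyl)methyl on an aromatic nitrogen. This change largely reverses the measured step from compound 1 to compound 2, since compound 4 carries 3-chloro-4-fluorophenyl where compound 1 carries 4-fluorophenyl on the same aromatic nitrogen. That step, a 3.8-fold higher number from compound 1 to compound 2 (0.58 log units; beyond the scatter), is the only one that bears on the question, and a drop of about its size is therefore expected, so that the step from compound 2 to compound 4 is estimated at a 4.6-fold lower number from compound 2 to compound 4 (0.66 log units; beyond the scatter). Compound 4 is expected to give about 7000 nM, most likely between 2500 nM and 20000 nM.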

Compound 4, half-maximal inhibitory concentration: 22700 nM
For compound 4 the middle estimate is 3.2-fold (0.51 log units) below the measured one, outside the stated range (above it).
By their numbers in this assay, from the lowest: compound 1; then compounds 4 and 2 (each within the scatter of the next). At a limit, above all of these: compound 3.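

In this assay, placing 3-chloro-4-fluorophenyl on the aromatic nitrogen in place of ((4-methoxyphenyl)carbamoyl)methyl gives a 1.4-fold lower number from compound 2 to compound 4 (0.15 log units; within the scatter), so these two groups, which differ in size and in hydrogen-bond donors and acceptors, cannot be told apart here. The single chloro in place of hydrogen on an aromatic carbon of the phenyl ring gives a 2.7-fold higher number from compound 1 to compound 4 (0.43 log units; beyond the scatter), which shows that the number at this position responds to a small change on the ring and not only to the kind of group attached to the nitrogen. Nothing measured here accounts for this effect of the chloro.

The compounds shown leave open whether a bromo or a methyl group in place of the chloro would move the number in the same way. They also leave open what an amine on the same phenyl ring would do.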